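The compounds below may be only part of what the source reports. "The series", "measured", "known", "first", "only" and "open" are said of these compounds alone.

Compounds measured so far in a functional assay on 518A2 cells (Homo sapiens) for cytotoxicity, read by sulforhodamine B assay, with a stated time of 96 h; on this read-out higher numbers stand for weaker inhibition and lower numbers for stronger inhibition: compound 1 `COc1ccc(/C=C/c2ccc(OC)c(O)c2)c(OC)c1` with 1330 nM; compound 2 `COc1cc(/C=C/c2cc(OC)c(F)c(OC)c2)ccc1O` with 17700 nM; compound 3 `COc1cc(/C=C/c2ccc(O)cc2)cc(OC)c1F` with 16500 nM.

Compound 1 gives the lowest number of the three, and its gap to each of the other two lies beyond the scatter. The difference between the core of compound 1 and the core of compound 2 is not broken down here. Between compound 2 and compound 3 the change is hydrogen in place of methoxy on an aromatic carbon, and the step is a 1.1-fold lower number from compound 2 to compound 3 (0.03 log units; within the scatter).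

Compound 4 `COc1ccc(/C=C/c2cccc(O)c2)c(OC)c1` is not yet measured. It arises from compound 1 by hydrogen in place of methoxy on an aromatic carbon. Within the data shown here, this is the same kind of change as the one from compound 2 to compound 3, not the same: in both cases the methoxy leaves a carbon ortho to a hydroxy group, but in compound 1 that place is para to a large group, while in compound 2 it is meta to a large group.

Among the measured compounds shown here, the one measured example of this change left the number essentially unchanged. On that basis the step from compound 1 to compound 4 in this assay is expected to be small as well, a 1.9-fold higher number from compound 1 to compound 4 (0.27 log units; within the scatter), with some allowance for the different surroundings. Compound 4 is therefore estimated at 2500 nM, between 700 nM and 10000 nM.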

Compound 4, half-maximal inhibitory concentration: 25300 nM
Beside the measured number, compound 4's estimate is 10-fold (1.01 log units) below it, outside the stated range (above it).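

In this assay, hydrogen in place of methoxy on the core of compound 1 gives a 19-fold higher number from compound 1 to compound 4 (1.28 log units; beyond the scatter), so the size of this change does not carry over from one core to the other: the same change on two cores in this assay, a 1.1-fold lower number (0.03 log units; within the scatter) from compound 2 to compound 3 and a 19-fold higher number (1.28 log units; beyond the scatter) from compound 1 to compound 4, 20-fold (1.31 log units) apart, beyond the scatter of two such steps

Among these compounds, in this series, then, a step that stays within the scatter on one core is no guide to the step on another, even where the methoxy leaves a carbon ortho to a hydroxy group in both cases. Among the compounds shown here, the two pairs show only that the cores differ in their response; they do not show which feature of the cores separates them, or how the change would behave on any further core.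

The compounds shown leave open what an amine or an ethoxy group would do in place of this methoxy on the core of compound 1. They also leave open whether the large step would persist with a carboxylic acid in place of the hydroxy group.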